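Swapping the aryl group on a triazole nitrogen

The source may hold more compounds than are shown below. What is called first, only, known or untested is meant among the compounds shown, and "the series" means these compounds.

Of the compounds shown here, three have been tested in a functional assay on A549 cells (Homo sapiens) for inhibition, read by sulforhodamine B assay, with a stated time of 48 h, tested at 50 uM; on this read-out higher numbers stand for more inhibition of growth at the one concentration tested and lower numbers for less inhibition of growth. Compound 1 `COc1ccc([C@@H]2C/C(=N/OCc3cn(-c4ccc(C(=O)c5ccccc5)cc4)nn3)c3cc(CC=C(C)C)c(OC)cc3O2)cc1` gives 34%, compound 2 `COc1ccc([C@@H]2C/C(=N/OCc3cn(-c4ccc(O)cc4)nn3)c3cc(CC=C(C)C)c(OC)cc3O2)cc1` gives 52%, and compound 3 `COc1ccc([C@@H]2C/C(=N/OCc3cn(-c4cc(OC)c(OC)c(OC)c4)nn3)c3cc(CC=C(C)C)c(OC)cc3O2)cc1` gives 28%, the lowest of the three numbers, with compound 1 within the scatter of it and compound 2 beyond. The measured steps were a number 18 percentage points higher from compound 1 to compound 2 (beyond the scatter) and a number 24 percentage points lower from compound 2 to compound 3 (beyond the scatter). Compound 4 `COc1ccc([C@@H]2C/C(=N/OCc3cn(-c4ccc(NC(C)=O)cc4)nn3)c3cc(CC=C(C)C)c(OC)cc3O2)cc1` is not yet measured; it differs from compound 3 by 4-acetamidophenyl in place of 3,4,5-trimethoxyphenyl on an aromatic nitrogen. Going by the values given here, both measured steps exchange the group on that same aromatic nitrogen and were modest, and the only group carrying a hydrogen-bond donor gave the highest number, so a modest rise in this assay is expected, a number 14 percentage points higher from compound 3 to compound 4 (beyond the scatter). Compound 4 is therefore estimated at 42%, between 25% and 60%.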

Compound 4, percent growth inhibition at one concentration: 19%
For compound 4 the middle estimate is 23 percentage points above the measured one; the measured number lies below the stated range.
By their numbers in this assay, from the lowest: compounds 4, 3 and 1 (each within the scatter of the next, the first and the last beyond it); then compound 2.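

In this assay, a hydrogen-bond donor on the aryl group does not by itself bring a high number: acetamido in place of hydroxy gives a number 33 percentage points lower from compound 2 to compound 4 (beyond the scatter). Acetamido in place of benzoyl gives a number 15 percentage points lower from compound 1 to compound 4 (beyond the scatter), while 4-acetamidophenyl in place of 3,4,5-trimethoxyphenyl gives a number 9 percentage points lower from compound 3 to compound 4 (within the scatter), so only the 4-hydroxyphenyl group of compound 2 stands apart from the other three. No measured evidence accounts for this. Going by these compounds, how a 4-aminophenyl group or a phenyl ring bearing a carboxylic acid on the same aromatic nitrogen would compare with compound 2 remains open.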